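Hydrazone aryl swap on two quinazoline cores

The compounds below may be only part of what the source reports. "The series", "measured", "known", "first", "only" and "open" are said of these compounds alone.

Measured so far in a functional assay on PC-3 cells (Homo sapiens) for cytotoxicity, read by MTT assay, with a stated time of 72 h; a lower number here means a stronger inhibitor, a higher number a weaker inhibitor:
- compound 1 `COc1cc(/C=N/NC(=O)Nc2cc3c(Nc4ccc(F)c(Cl)c4)ncnc3cc2O[C@H]2CCOC2)cc(OC)c1OC` gives 29600 nM
- compound 2 `O=C(N/N=C/c1ccc(O)c(Br)c1)Nc1cc2c(Nc3ccc(F)c(Cl)c3)ncnc2cc1O[C@H]1CCOC1` gives 5230 nM
- compound 3 `COc1cc2ncnc(Nc3ccc(F)c(Cl)c3)c2cc1NC(=O)N/N=C/c1cc(OC)c(OC)c(OC)c1` gives 36500 nM

Compounds 1 and 3 share everything but the group on the oxygen on the aromatic ring: methyl in place of oxolan-3-yl on an oxygen on an aromatic ring. Within the data shown here, that difference between the two cores barely registers in this assay, with a 1.2-fold higher number from compound 1 to compound 3 (0.09 log units; within the scatter), so the two cores can be treated as interchangeable on present evidence, though only this one pair supports that.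

The other change in the set is at the carbon with a double bond to nitrogen: 3-bromo-4-hydroxyphenyl in place of 3,4,5-trimethoxyphenyl on a carbon with a double bond to nitrogen. Made on the core of compound 1, it gives a 5.7-fold lower number from compound 1 to compound 2 (0.75 log units; beyond the scatter), a modest but real gain.

Compound 4 `COc1cc2ncnc(Nc3ccc(F)c(Cl)c3)c2cc1NC(=O)N/N=C/c1ccc(O)c(Br)c1` is not yet measured. It carries the same change on the core of compound 3: 3-bromo-4-hydroxyphenyl in place of 3,4,5-trimethoxyphenyl on a carbon with a double bond to nitrogen. The place description of the change matches that of the change from compound 1 to compound 2 word for word, so this is the same change on a core that differs only by methyl in place of oxolan-3-yl on an oxygen on an aromatic ring.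

Since the core difference was within the scatter by a 1.2-fold higher number from compound 1 to compound 3 (0.09 log units; within the scatter), the same change is expected to repeat what was seen in this assay as a 5.7-fold lower number from compound 1 to compound 2 (0.75 log units; beyond the scatter). On that basis the step is estimated as a 5.7-fold lower number from compound 3 to compound 4 (0.76 log units; beyond the scatter). This rests on a single precedent, so the range is kept wide. Compound 4 is expected to give about 6400 nM, between 2800 nM and 15000 nM.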

Compound 4, half-maximal inhibitory concentration: 15300 nM
Estimate against measurement, compound 4: 2.4-fold (0.38 log units) below; measured number above the stated range.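

In this assay, 3-bromo-4-hydroxyphenyl in place of 3,4,5-trimethoxyphenyl again lowers the number on the second core, with a 2.4-fold lower number from compound 3 to compound 4 (0.38 log units; beyond the scatter), so the direction of the change carries over and its size on the two cores cannot be told apart: the same change on two cores in this assay, a 5.7-fold lower number (0.75 log units; beyond the scatter) from compound 1 to compound 2 and a 2.4-fold lower number (0.38 log units; beyond the scatter) from compound 3 to compound 4, 2.4-fold (0.38 log units) apart, within the scatter of two such steps. Read the other way, methyl in place of oxolan-3-yl gives a 2.9-fold higher number from compound 2 to compound 4 (0.47 log units; beyond the scatter), a step beyond the scatter where the earlier one on the 3,4,5-trimethoxyphenyl compounds was within it, yet these two steps cannot be separated either: the same change on two cores in this assay, a 1.2-fold higher number (0.09 log units; within the scatter) from compound 1 to compound 3 and a 2.9-fold higher number (0.47 log units; beyond the scatter) from compound 2 to compound 4, 2.4-fold (0.38 log units) apart, within the scatter of two such steps. This supports carrying the change across these two cores as a lowering of the number of modest size, but it does not show that the size is fixed or that it depends on the core, and it rests on two pairs only.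

Open, from the compounds shown here alone, is whether the gain belongs to the bromine, to the hydroxyl or to the two together on the phenyl ring. Also open, going by these compounds, is how the change behaves with another group on the oxygen on the aromatic ring, such as a longer chain or a chain ending in an amine.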